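Hydrogen in Place of Methyl: Expecting Compound 4

This account rests on a few compounds, and the source may have more. Where it says the series, first, only, none or still open, it means among the compounds named here.

Compound 1 `COc1cc(-c2nn(-c3cccc(NC(=O)Nc4cc(C(F)(F)F)cc(C(F)(F)F)c4)c3)cc2-c2ccncc2)ccc1Cl` and compound 2 `COc1cc(-c2nn(-c3cccc(NC(=O)Nc4ccc(Cl)c(Cl)c4)c3)cc2-c2ccncc2)ccc1Cl` carry different groups at one end of the molecule; the difference between the two cores is not broken down here. In a functional assay on T47D cells (Homo sapiens) for inhibition, read by sulforhodamine B assay, with a stated time of 48 h (on this read-out lower numbers stand for stronger inhibition of growth and higher numbers for weaker inhibition of growth), compound 1 gives 1550 nM, while compound 2 gives 1420 nM, two numbers within the scatter of each other. Compound 3 `O=C(Nc1cccc(-n2cc(-c3ccncc3)c(-c3ccc(Cl)c(O)c3)n2)c1)Nc1ccc(Cl)c(Cl)c1` comes from compound 2 through one change, (hydrogen in place of methyl on an oxygen on an aromatic ring), and in this assay compound 3 gives 1550 nM, a step of a 1.1-fold higher number from compound 2 to compound 3 (0.04 log units; within the scatter). Compound 4 `O=C(Nc1cccc(-n2cc(-c3ccncc3)c(-c3ccc(Cl)c(O)c3)n2)c1)Nc1cc(C(F)(F)F)cc(C(F)(F)F)c1` is compound 1 with the same change, (hydrogen in place of methyl on an oxygen on an aromatic ring), at the same place. A similarly small step is expected, a 1.1-fold higher number from compound 1 to compound 4 (0.04 log units; within the scatter), because the matching step a 1.1-fold higher number from compound 2 to compound 3 (0.04 log units; within the scatter) stayed within the usual scatter. Compound 4 is therefore estimated at about 1700 nM, most likely between 800 nM and 3600 nM.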

Compound 4, concentration for 50% growth inhibition: 1820 nM
For compound 4 the middle estimate is 1.1-fold (0.03 log units) below the measured one, within the range that was stated.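

In this assay going from methoxy to hydroxy gives a 1.2-fold higher number from compound 1 to compound 4 (0.07 log units; within the scatter) and so leaves the read-out about where it was. Set beside the earlier step, the two cores agree: the same change on two cores in this assay, a 1.1-fold higher number (0.04 log units; within the scatter) from compound 2 to compound 3 and a 1.2-fold higher number (0.07 log units; within the scatter) from compound 1 to compound 4, 1.1-fold (0.03 log units) apart, within the scatter of two such steps. The change therefore carries between these two cores without a step beyond the scatter, but this does not show that it would do the same on any other core, and it does not explain why the numbers stay so close.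

The compounds shown leave open what a longer chain on that oxygen, such as ethyl or propyl, would do. They also leave open what an amine in place of the hydroxy would do.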